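Cytotoxicity notes: amide aryl swap in the sulfoxide series

A few compounds are considered here, and "the series" means these few. Any claim that something is new, unique, unknown or untested is made for them only; others in the source may bear on it.

Measured so far in an ADME assay on MT4 cells (Homo sapiens) for cytotoxicity, read by MTT assay, with a stated time of 5 days; a higher number here means that more compound is tolerated, a lower number that less compound is tolerated:
- compound 1 `COc1cc2nc(Nc3ccc(C#N)cc3)nc(Nc3c(Cl)cc(/C=C/C#N)cc3Cl)c2cc1OC`: 9920 nM
- compound 2 `COc1cc2nc([S+]([O-])CC(=O)Nc3ccccc3[N+](=O)[O-])nc(Nc3c(Cl)cc(/C=C/C#N)cc3Cl)c2cc1OC`: > 199000 nM

Compound 2 reached no number in this assay; its value is a limit, (the limit of > 199000 nM in this assay, at which 1 of the 2 values shown sits), so its position is known only as sitting at that edge. Compound 1 gives a measured value in this assay and stands well inside the measured range. For the measured compounds named here, no step between measured compounds is available, so nothing is known about how changes on the amide-type nitrogen move this read-out.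

Compound 3 `COc1cc2nc([S+]([O-])CC(=O)Nc3ccc(S(N)(=O)=O)cc3)nc(Nc3c(Cl)cc(/C=C/C#N)cc3Cl)c2cc1OC` differs from compound 2 in one place: 4-sulfamoylphenyl in place of 2-nitrophenyl on an amide-type nitrogen. Going by the values given here, the only anchor is compound 2 at its limit, so compound 3 is expected to stay at or near that limit, with the step of a number no higher from compound 2 to compound 3 (the limit leaves the size open) expected to be none beyond the scatter. Compound 3 is accordingly estimated at 199000 nM, within 70000 nM to 400000 nM, most likely again reported as a limit.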

Compound 3, half-maximal cytotoxic concentration: > 189000 nM
Compound 3 gave a limit, no number; the forecaster's own chance of this, stated with the estimate: 70%; the middle value lies beyond the limit too.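

For the compounds shown here, compound 2 and compound 3 both end as limits in this assay, and no step between them can be read. The compounds shown leave open whether 4-sulfamoylphenyl in place of 2-nitrophenyl on an amide-type nitrogen moves this read-out at all.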